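The source may hold more compounds than are shown below. What is called first, only, known or untested is meant among the compounds shown, and "the series" means these compounds.

Measured compounds:
- compound 1, `Cc1ncsc1C(=O)NCCC1CCN(S(=O)(=O)NC(=O)NC[C@@H]2C[C@@H]3C=C[C@@H]2C3)CC1`: 11%
- compound 2, `O=C(NC[C@@H]1C[C@@H]2C=C[C@@H]1C2)NS(=O)(=O)N1CCC(CCNC(=O)c2cc(Cl)ccn2)CC1`: 32%
- compound 3, `O=C(NC[C@@H]1C[C@@H]2C=C[C@@H]1C2)NS(=O)(=O)N1CCC(CCNC(=O)c2nc3ccccc3s2)CC1`: 24%

The three compounds share one core and differ only in the ring attached to a carbonyl carbon. In a functional assay on the whole organism (blood) with Rattus norvegicus as the target, with stated times of 24 h and 1 h, at a dose of 5 mg/kg by the intraperitoneal route (a higher number here means a stronger effect of the compound at the dose given, a lower number a weaker effect), compound 3 stands second of the three. Its gap to compound 2 lies within the scatter, a number 8 percentage points lower from compound 2 to compound 3 (within the scatter), so the two cannot be ranked against each other. Its gap to compound 1 is larger: a number 13 percentage points higher from compound 1 to compound 3 (beyond the scatter), and the other change at the same place gave a number 21 percentage points higher from compound 1 to compound 2 (beyond the scatter).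

Compound 4, `O=C(NC[C@@H]1C[C@@H]2C=C[C@@H]1C2)NS(=O)(=O)N1CCC(CCNC(=O)c2ccc3ccccc3n2)CC1`, has not yet been measured. It differs from compound 3 by quinolin-2-yl in place of 1,3-benzothiazol-2-yl on a carbonyl carbon. For the measured compounds named here, no measured step swaps one bicyclic aromatic ring for another, so the only guide is that exchanging rings at this carbonyl carbon has moved the number modestly at most, and the step from compound 2 to compound 3 stayed within the scatter. Compound 4 is therefore expected to land close to compound 3, with a step of a number 2 percentage points higher from compound 3 to compound 4 (within the scatter), and the estimate for compound 4 is 26%, within 10% to 42%.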

Compound 4, a percentage reported as activity, at one dose (the size of the read-out at that dose, not a potency): 21%
For compound 4 the middle estimate is 5 percentage points above the measured one; measured number inside the range.
By their numbers in this assay, from the lowest: compounds 1, 4, 3 and 2 (each within the scatter of the next, the first and the last beyond it).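

In this assay, swapping the 1,3-benzothiazol-2-yl for quinolin-2-yl on the carbonyl carbon gives no readable change (a number 3 percentage points lower from compound 3 to compound 4 (within the scatter)), so these two fused aromatic ring pairs cannot be told apart here, even though one has a sulfur atom and a five-membered ring and the other has neither. The comparison with the other rings is less even: the step to 4-chloropyridin-2-yl is beyond the scatter (a number 11 percentage points lower from compound 2 to compound 4 (beyond the scatter)), while the step to 4-methyl-1,3-thiazol-5-yl is not (a number 10 percentage points higher from compound 1 to compound 4 (within the scatter)). No measurement at hand gives a cause for any of these steps.

The compounds shown leave open how a plain phenyl ring, or a ring bearing an amine or a carboxylic acid, would behave on this carbonyl carbon. They also leave open whether a longer chain in the shared core would change these readings.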